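Back to a five-membered ring on the shared core

A few compounds are considered here, and "the series" means these few. Any claim that something is new, unique, unknown or untested is made for them only; others in the source may bear on it.

For the measured compounds named here, compound 2 `COc1cccc(Nc2nccc(-c3ccncc3)n2)c1` gives 400 nM in a functional assay for inhibition, with Homo sapiens as the target (a higher number here means a weaker inhibitor, a lower number a stronger inhibitor), the lower of the two numbers so far; compound 1 `COc1cccc(Nc2nccc(-c3ccc(C)o3)n2)c1` gives 1500 nM. Compound 3 `COc1cccc(Nc2nccc(-c3sccc3C)n2)c1` carries 3-methylthiophen-2-yl in place of pyridin-4-yl on an aromatic carbon. Going by the values given here, the one measured step that bears on this is a 3.8-fold lower number from compound 1 to compound 2 (0.57 log units; beyond the scatter), which went from a five-membered aromatic ring with one hetero atom to pyridin-4-yl. Compound 3 reverses that kind of change, so compound 3 is expected to lose ground, with a 3.0-fold higher number from compound 2 to compound 3 (0.48 log units; beyond the scatter) roughly undoing the earlier gain, though its ring and hetero atom differ from those of compound 1. The estimate for compound 3 is 1200 nM, with a range of 500 nM to 3000 nM.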

Compound 3, half-maximal inhibitory concentration: > 24000 nM
Compound 3 ended at the assay's limit; the forecaster's own chance of this, stated with the estimate: 5%; middle value at least 20-fold (1.30 log units) from the limit.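

Compound 3 stands at a limit of the assay, not at a number: the limit of > 24000 nM in this assay, at which 1 of the 3 values shown sits. The exchange of pyridin-4-yl for 3-methylthiophen-2-yl gives an at least 60-fold higher number from compound 2 to compound 3 (1.77 log units; beyond the scatter), a far larger step than the one earlier seen at this position. Five-membered aromatic rings are also not interchangeable here, with an at least 16-fold higher number from compound 1 to compound 3 (1.20 log units; beyond the scatter).

Going by these compounds, whether the loss follows the sulfur or the methyl of 3-methylthiophen-2-yl stays open. Also open, on these data alone, is how an unsubstituted thiophen-2-yl or a pyridin-3-yl would read on the shared core.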